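Benzyl para-substituent swap on the shared amide core

The source may hold more compounds than are shown below. What is called first, only, known or untested is meant among the compounds shown, and "the series" means these compounds.

Measured so far:
compound 1 `COc1cc(N)c(Cl)cc1NC(=O)C1CCN(C2CCCC2)CC1`, in a functional assay on the whole organism for antagonist activity, with Mus musculus as the target (on this read-out lower numbers stand for an effect already at smaller amounts and higher numbers for an effect only at larger amounts of compound), compound 1 gives > 10 mg/kg, a limit of the assay and not a number.
compound 2 `COc1cc(N)c(Cl)cc1NC(=O)C1CCN(Cc2ccc(O)cc2)CC1`, in this assay compound 2 gives > 8 mg/kg, likewise a limit and not a number.

Compound 2 therefore stands only at a limit; the step that the two limits leave unreadable from compound 1 to compound 2 cannot be sized because the limit of > 10 mg/kg in this assay, at which 1 of the 2 values shown sits, and the limit of > 8 mg/kg in this assay, at which 1 of the 2 values shown sits, cap both ends of it.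

Compound 3 `COc1cc(N)c(Cl)cc1NC(=O)C1CCN(Cc2ccc(F)cc2)CC1` carries the change fluoro in place of hydroxy on an aromatic carbon relative to compound 2. Among the measured compounds shown here, no measured step bears on this particular change: the single step from compound 1 to compound 2 exchanges the whole substituent on the ring nitrogen, not the para group. With both anchors at limits, the expected step that the limit leaves unreadable from compound 2 to compound 3 is none beyond the scatter. Compound 3 is estimated at 12 mg/kg in this assay, within 5 mg/kg to 30 mg/kg, most likely reported again as a limit.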

Compound 3, dose for half-maximal effect: 0.6 mg/kg
Estimate against measurement, compound 3: 20-fold (1.30 log units) above; the measured number lies below the stated range.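

The group on the aromatic carbon, para to a large group, matters in this assay: fluoro in place of hydroxy gives an at least 13-fold lower number from compound 2 to compound 3 (1.12 log units; beyond the scatter), so a benzyl group on the ring nitrogen is compatible with an effect at low doses. Exchange of cyclopentyl for 4-fluorobenzyl on the amine nitrogen in the ring gives an at least 16-fold lower number from compound 1 to compound 3 (1.22 log units; beyond the scatter), and of the three compounds shown only compound 3 has a measured number. The step from hydroxy to fluoro is only a minimum size because compound 2 stands at a limit: the limit of > 8 mg/kg in this assay, at which 1 of the 3 values shown sits.

The step from compound 1 to compound 2 cannot be read, and with a single measured number the compounds shown do not tell whether the gain is specific to fluoro. Chloro, methoxy or an amine at the same place, or 4-fluorophenethyl on the ring nitrogen, would test this.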